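A few compounds are considered here, and "the series" means these few. Any claim that something is new, unique, unknown or untested is made for them only; others in the source may bear on it.

Working notes on the series in a functional assay on HEK293 cells for positive allosteric modulation of metabotropic glutamate receptor 5 (Homo sapiens), read by calcium flux; on this read-out lower numbers stand for smaller maximal responses and higher numbers for larger maximal responses.

Three compounds have numbers in this assay. Compound 1 `O=C(c1ccc(F)cc1)N1CCc2nc(COc3cccnc3)oc2C1` gives 40%. Compound 2 `O=C(c1cc2ccccc2[nH]1)N1CCc2nc(COc3ccccc3)oc2C1` gives 40%, level with compound 1 at the digits shown, the two together being the lowest pair of the three. Among the compounds with values here, compound 3 `Cn1c(C(=O)N2CCc3nc(COc4ccccc4)oc3C2)cc2ccccc21` gives 57%; the only measured single-point step, a number 17 percentage points higher from compound 2 to compound 3 (beyond the scatter), lies beyond the scatter and is modest in size. So compound 2 sits at the low end of the series, with compound 1 within the scatter of it and compound 3 above it.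

Compound 4 `O=C(c1n[nH]c2ccncc12)N1CCc2nc(COc3ccccc3)oc2C1` is not yet measured. It differs from compound 2 as follows: a group of 9 heavy atoms (6 carbon, 3 nitrogen; one five-membered aromatic ring with 2 hetero atoms, one six-membered aromatic ring with 1 hetero atom) in place of a group of 9 heavy atoms (8 carbon, 1 nitrogen; one five-membered aromatic ring with 1 hetero atom, one six-membered aromatic ring of carbon only), on a carbonyl carbon. Within the data shown here, no measured step swaps one bicyclic amide-side group for another; the one step that touches this part of the molecule, from compound 2 to compound 3, alters only the hydrogen on the aromatic nitrogen and moves the maximal response by a modest amount. The present change is larger in kind, and its direction cannot be read from the data.

For compound 4 the maximal response is estimated at 45%, with a range from 25% to 65%; the implied step a number 5 percentage points higher from compound 2 to compound 4 (within the scatter) is expected to be small, of uncertain sign.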

Compound 4, largest response reached (reported as percent of maximum), in percent of the reference or control that the assay uses: 53%
Compound 4: middle estimate off by 8 percentage points, on the low side; low and high end bracket the measured number.
By their numbers in this assay, from the lowest: compounds 1 and 2 (each within the scatter of the next); then compounds 4 and 3 (each within the scatter of the next).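

In this assay, replacing the 1H-indol-2-yl group on the carbonyl carbon with the more nitrogen-rich bicyclic group gives a number 13 percentage points higher from compound 2 to compound 4 (beyond the scatter), so the maximal response at this position responds to a change of the whole bicyclic group and not only to methyl on the aromatic nitrogen. The entering group still carries a hydrogen-bond donor, yet compound 4 at 53% and the nitrogen-methylated compound 3 at 57% lie within the scatter of each other, so a response at this level does not require the loss of that hydrogen. No measurement on hand bears on why the response changes with this swap.

On these data alone, the step alters the five-membered and six-membered rings together, so the contribution of each ring's change remains open. Also open, as far as these compounds go, are whether methyl on the aromatic nitrogen of compound 4 would repeat the change seen as a number 17 percentage points higher from compound 2 to compound 3 (beyond the scatter), and how a saturated amine such as piperidine or a carboxylic acid on the bicyclic group would read in this assay.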